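The source may report more compounds than this note shows. Statements on the series, on what has been measured and on what is new or still open speak of the compounds shown alone.

Measured compounds in a functional assay on SF-268 cells (Homo sapiens) for inhibition, read by sulforhodamine B assay, with a stated time of 48 h, tested at 10 uM; a higher number here means more inhibition at the concentration tested (going by the name of the read-out), a lower number less inhibition:
compound 1 `Fc1ccc(-c2cn3ccnc3c(-c3ccc4ncn(C5CCCCC5)c4c3)n2)cc1` gives 10.7%
compound 2 `Brc1ccc(-c2cn3ccnc3c(-c3ccc4ncn(C5CCCCC5)c4c3)n2)cc1` gives 15.5%

Compound 1 holds the lower of the two numbers, and compound 2 sits close to it: the step of a number 4.8 percentage points higher from compound 1 to compound 2 (within the scatter) is within the scatter, so the two values cannot be told apart on this series alone.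

The untested member is compound 3 `Fc1ccccc1-c1cn2ccnc2c(-c2ccc3ncn(C4CCCCC4)c3c2)n1`. It differs from compound 1 by 2-fluorophenyl in place of 4-fluorophenyl on an aromatic carbon. Among the measured compounds shown here, the one measured step, fluoro replaced by bromo on the 4-fluorophenyl group, bears on this change only loosely: it shows that a swap of the halogen at that position left this assay essentially unmoved, and it says nothing about moving the fluorine to another carbon of the same ring. For the measured compounds named here, no measured pair covers a 2-fluorophenyl group. Going by the values given here, with the sole comparison flat, the expectation for compound 3 is no step beyond the scatter, and the estimated step of a number 1.3 percentage points higher from compound 1 to compound 3 (within the scatter) is expected to stay within it. The value for compound 3 in this assay is expected to be 12%, with a range from 0% to 30%.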

Compound 3, a percentage reported as inhibition, at one concentration (the size of the read-out at that concentration, not a potency): 6.04%
Estimate against measurement, compound 3: 6 percentage points above; the measured number falls inside the stated range.
By their numbers in this assay, from the lowest: compounds 3, 1 and 2 (each within the scatter of the next).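

Within this assay, the position of the fluorine on the phenyl ring now has a direct reading: 2-fluorophenyl in place of 4-fluorophenyl, with the same atoms in the group, gives a number 4.7 percentage points lower from compound 1 to compound 3 (within the scatter). Against the bromo member, 2-fluorophenyl in place of 4-bromophenyl gives a number 9.5 percentage points lower from compound 2 to compound 3 (within the scatter), so the largest gap among the three compounds also stays inside the scatter and the series shows no measurable dependence on either the identity of this halogen or the two fluorine positions at this one concentration. No measured evidence on the compounds bears on this flat result, and the data offer no explanation for it.

As far as these compounds go, the three compounds span only halogenated phenyl groups on an aromatic carbon of the shared core, so it remains open whether a different group at this place, such as a phenyl ring carrying an amine or a carboxylic acid, would give a step beyond the scatter. Also open, from the compounds shown here alone, is how 3-fluorophenyl would read, and whether these small numbers at a single concentration would hold at other concentrations.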